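This account rests on a few compounds, and the source may have more. Where it says the series, first, only, none or still open, it means among the compounds named here.

Series notes. Compound 3 `CC(C)[C@H](C(=O)Nc1ncc[nH]1)c1ccc(Cl)cc1` gives the lowest of the three values measured in a functional assay on CHO cells for agonist activity at Free fatty acid receptor 2 (Homo sapiens), read by cAMP accumulation (a lower number here means a smaller maximal response, a higher number a larger maximal response), at 55%; compound 1 `CNC(=O)[C@H](c1ccc(Cl)cc1)C(C)C` gives 66% and compound 2 `CC(C)[C@H](C(=O)Nc1nncs1)c1ccc(Cl)cc1` gives 115%. Compound 4 `CC(C)[C@H](C(=O)NC1=NC(=O)CS1)c1ccc(Cl)cc1` is still to be measured; it differs from compound 3 by a group of 6 heavy atoms (3 carbon, 1 nitrogen, 1 oxygen, 1 sulfur; one five-membered non-aromatic ring with 2 hetero atoms) in place of a group of 5 heavy atoms (3 carbon, 2 nitrogen; one five-membered aromatic ring with 2 hetero atoms), on an amide-type nitrogen. The relevant steps all change the group on the amide-type nitrogen: a number 60 percentage points lower from compound 2 to compound 3 (beyond the scatter), a number 49 percentage points higher from compound 1 to compound 2 (beyond the scatter) and a number 11 percentage points lower from compound 1 to compound 3 (beyond the scatter). The entering ring resembles the 1,3,4-thiadiazol-2-yl of compound 2 in holding one sulfur and no hydrogen-bond donor, and compound 2 gave 115%. For compound 4 a rise beyond the scatter is therefore expected, a number 35 percentage points higher from compound 3 to compound 4 (beyond the scatter), though a non-aromatic ring is new to the set. Compound 4 is estimated at 90% in this assay, within 55% to 125%.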

Compound 4, largest response reached (reported as efficacy), in percent of the reference or control that the assay uses: 96%
Estimate against measurement, compound 4: 6 percentage points below; low and high end bracket the measured number.
By their numbers in this assay, from the lowest: compound 3; then compound 1; then compound 4; then compound 2.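

In this assay the non-aromatic ring on the amide-type nitrogen gives a response well clear of the 1H-imidazol-2-yl (a number 41 percentage points higher from compound 3 to compound 4 (beyond the scatter)) and of the methyl (a number 30 percentage points higher from compound 1 to compound 4 (beyond the scatter)), so among these compounds an aromatic ring is not needed to exceed compound 1. It still falls short of the 1,3,4-thiadiazol-2-yl (a number 19 percentage points lower from compound 2 to compound 4 (beyond the scatter)). No measured evidence accounts for these steps.

The compounds shown do not separate the part played by the ring sulfur from that of the ring carbonyl. From the compounds shown here alone, how a pyridin-2-yl or an acetyl group on this nitrogen would compare also stays open.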